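A few compounds are considered here, and "the series" means these few. Any claim that something is new, unique, unknown or untested is made for them only; others in the source may bear on it.

Measured so far:
- compound 1, `Cc1cc(C(=O)Nc2ccccc2)nn1Cc1cc(Cl)ccc1OCc1ccccc1`: 39.8 nM
- compound 2, `Cc1cc(C(=O)Nc2ccc(F)cc2)nn1Cc1cc(Cl)ccc1OCc1ccccc1`: 79.4 nM
- compound 3, `Cc1cc(NC(=O)CC(C)(C)C)nn1Cc1cc(Cl)ccc1OCc1ccccc1`: 10 nM

Among these three values in an assay on CHO-K1 cells for displacement of a labelled ligand from prostaglandin E2 receptor EP1 subtype (Homo sapiens) (on this read-out lower numbers stand for stronger inhibition and higher numbers for weaker inhibition), compound 1 stands second highest. Compound 2 lies nearest, with a 2.0-fold higher number from compound 1 to compound 2 (0.30 log units; within the scatter), and compound 3 lies furthest, with a 4.0-fold lower number from compound 1 to compound 3 (0.60 log units; beyond the scatter).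

Compound 4, `Cc1cc(NC(=O)c2c(F)cccc2F)nn1Cc1cc(Cl)ccc1OCc1ccccc1`, has not yet been measured. It differs from compound 1 in one place: ((2,6-difluorophenyl)carbonyl)amino in place of phenylcarbamoyl on an aromatic carbon. Within the data shown here, the step that bears most directly on this change is the one from compound 1 to compound 3, where (neopentylcarbonyl)amino replaced phenylcarbamoyl and gave a 4.0-fold lower number from compound 1 to compound 3 (0.60 log units; beyond the scatter); the step from compound 2 to compound 3, with the same kind of replacement, gave a 7.9-fold lower number from compound 2 to compound 3 (0.90 log units; beyond the scatter). Among the measured compounds shown here, in compound 4 the group that enters is also a carbonylamino group, though carrying a 2,6-difluorophenyl rather than a neopentyl, so a modest step toward a lower number is expected, smaller than or similar to the one seen for compound 3.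

For compound 4 the expected value in this assay is 16 nM, with a range from 5 nM to 50 nM. This expectation corresponds to a 2.5-fold lower number from compound 1 to compound 4 (0.40 log units; beyond the scatter).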

Compound 4, half-maximal inhibitory concentration: 12.6 nM
The estimate for compound 4 lay 1.3-fold (0.10 log units) above the measured number; measured number inside the range.
By their numbers in this assay, from the lowest: compounds 3 and 4 (each within the scatter of the next); then compounds 1 and 2 (each within the scatter of the next).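

At this position on the five-membered ring, the amide can be attached through its nitrogen and still give lower numbers with an aromatic ring beyond the carbonyl: there is a 3.2-fold lower number from compound 1 to compound 4 (0.50 log units; beyond the scatter) and a 6.3-fold lower number from compound 2 to compound 4 (0.80 log units; beyond the scatter), so the neopentyl of compound 3 is not required for this gain. Replacing neopentyl with 2,6-difluorophenyl on the carbonyl carbon leaves the two compounds within the scatter, with a 1.3-fold higher number from compound 3 to compound 4 (0.10 log units; within the scatter). No supporting evidence is available to explain these differences.

A plain (phenylcarbonyl)amino group at this position would help separate the effect of the reversed amide from that of the two fluorines. An amine or a carboxylic acid on the same ring carbon would test whether any amide is needed there.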